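A few compounds are considered here, and "the series" means these few. Any claim that something is new, unique, unknown or untested is made for them only; others in the source may bear on it.

Working notes on the series. Within the data shown here, in an assay on CHO cells for displacement of a labelled ligand from Substance-P receptor (Homo sapiens) (on this read-out lower numbers stand for stronger inhibition and higher numbers for weaker inhibition), compound 3 `COc1ccccc1[C@H]1COC2(CCCNC2c2ccccc2)C1` gives 6.5 nM, the second highest of the three numbers so far. Compound 1 `COc1ccc(OC(F)(F)F)cc1C1=CC2(CCCNC2c2ccccc2)OC1` gives 0.35 nM in this assay, and compound 2 `c1ccc([C@H]2COC3(CCCN[C@H]3c3ccccc3)C2)cc1` gives 133 nM. Compound 2 lacks the methoxy group of compound 3, and both gaps to compound 3 lie beyond the scatter. Compound 4 `COc1ccc(-n2nnnc2C(F)(F)F)cc1[C@H]1COC2(CCCNC2c2ccccc2)C1` differs from compound 3 by 5-(trifluoromethyl)-1H-tetrazol-1-yl in place of hydrogen on an aromatic carbon. Among the measured compounds shown here, no measured pair shows this exact change. Further substitution of the aryl ring, as in compound 1 with 0.35 nM, goes with a lower number, so a step downward beyond the scatter is expected, of the size a 6.5-fold lower number from compound 3 to compound 4 (0.81 log units; beyond the scatter). Compound 4 is therefore estimated at 1 nM, with a range of 0.3 nM to 3.5 nM.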

Compound 4, half-maximal inhibitory concentration: 0.11 nM
Compound 4: middle estimate off by 9.1-fold (0.96 log units), on the high side; the whole stated range lies above it.
By their numbers in this assay, from the lowest: compound 4; then compound 1; then compound 3; then compound 2.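

In this assay the 5-(trifluoromethyl)-1H-tetrazol-1-yl group in place of hydrogen, on the aromatic carbon para to a methoxy group, gives a 59-fold lower number from compound 3 to compound 4 (1.77 log units; beyond the scatter) on the shared core. Among these compounds, this is the first single-place step, and it shows that this aromatic carbon can carry a second aromatic ring while the number falls. Nothing at hand accounts for the size of this step. The compounds shown leave open whether the tetrazole ring or its trifluoromethyl group goes with the step, and how a nitrile or an amine would read at this carbon.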